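The compounds below may be only part of what the source reports. "The series", "measured", "known", "first", "only" and "open" are said of these compounds alone.

Measured so far:
compound 1, `Clc1ccc(Cc2nn3c(Br)c(-c4ccc(Br)cc4)nc3s2)cc1`, > 250000 nM
compound 2, `O=[N+]([O-])c1ccc(-c2nc3sc(Cc4ccc(Cl)cc4)nn3c2Br)cc1`, 94000 nM

Both compounds share one core and differ in one group on the outer phenyl ring. In a functional assay on L1210 cells (Mus musculus) for cytotoxicity, with a stated time of 48 h (on this read-out lower numbers stand for stronger inhibition and higher numbers for weaker inhibition), compound 1 gives > 250000 nM, which is a limit of the assay rather than a number. In this assay compound 2 gives 94000 nM. Among the compounds with values here, the step of an at least 2.6-fold lower number from compound 1 to compound 2 (0.42 log units; beyond the scatter), the only measured step, came with nitro in place of bromo on an aromatic carbon. Among the numbers shown, compound 2 therefore holds the only actual value, the other entry being a limit.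

Compound 3, `N#CSc1c(-c2ccc([N+](=O)[O-])cc2)nc2sc(Cc3ccc(Cl)cc3)nn12`, keeps the nitro group and changes the core instead: cyanosulfanyl in place of bromo on an aromatic carbon. Within the data shown here, no measured step touches this position; the one step available, an at least 2.6-fold lower number from compound 1 to compound 2 (0.42 log units; beyond the scatter), concerns a different place and a different group, so it gives no direct guide. For this change a step within the usual scatter is expected for compound 3, in either direction, a 1.2-fold lower number from compound 2 to compound 3 (0.07 log units; within the scatter). A reading that comes back only as a limit remains possible because the limit of > 250000 nM in this assay, at which 1 of the 2 values shown sits, shows that such readings occur here. The estimate for compound 3 in this assay is 80000 nM, from 25000 nM to 250000 nM.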

Compound 3, half-maximal inhibitory concentration: 50000 nM
Compound 3: the middle estimate sits 1.6-fold (0.20 log units) above what was measured, and the stated range covers the measured number.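

In this assay, within the data shown here, replacing bromo with cyanosulfanyl gives a 1.9-fold lower number from compound 2 to compound 3 (0.27 log units; within the scatter), the first measured step at this aromatic carbon of the five-membered aromatic ring with 2 nitrogen, and this step cannot be told apart from repeat-measurement noise. Compound 3 therefore shows that, with the nitro group kept, this place can carry cyanosulfanyl, with 3 heavy atoms and 2 hydrogen-bond acceptors, in place of bromo, with 1 heavy atom and no hydrogen-bond acceptors, without a change that the assay can resolve. The reading for compound 3 is also an actual number rather than a limit, a kind of entry that does occur here: the limit of > 250000 nM in this assay, at which 1 of the 3 values shown sits.

With only bromo and cyanosulfanyl shown at this place, it remains open whether a different group, such as an amine, a carboxylic acid or a longer chain, would move the number beyond the scatter in either direction. On these data alone, it also remains open whether cyanosulfanyl would give a similar reading with bromo rather than nitro on the outer phenyl ring.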